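The source may report more compounds than this note shows. Statements on the series, on what has been measured and on what is new or still open speak of the compounds shown alone.

Measured so far:
compound 1, `CC(C)[C@@H](C)NC(=O)c1ccc(C#Cc2cccc(F)c2)cn1`: 69.3%
compound 2, `O=C(NCC1CC1)c1ccc(C#Cc2cccc(F)c2)cn1`: 61.4%

In a functional assay on HEK293 cells for positive allosteric modulation of metabotropic glutamate receptor 5 (Rattus norvegicus), read by fluorescence and calcium flux (on this read-out higher numbers stand for larger maximal responses and lower numbers for smaller maximal responses), compound 1 gives 69.3%. Compound 2 gives 61.4%. Compound 2 holds the lowest of the two numbers, but its nearest neighbour, compound 1, sits within the scatter of it, so the two read-outs cannot be told apart.

The unmeasured compound 3, `O=C(NCC1CCC1)c1ccc(C#Cc2cccc(F)c2)cn1`, differs from compound 2 in one place: cyclobutyl in place of cyclopropyl on a saturated chain carbon bound to an amide-type nitrogen. Within the data shown here, the one measured step that touches the same part of the molecule is a number 7.9 percentage points lower from compound 1 to compound 2 (within the scatter), where a different group on the amide-type nitrogen left the maximal response within the scatter. That change was a larger one than the move from cyclopropylmethyl to cyclobutylmethyl, which adds a single ring carbon. The measured data give no sign that the amide-type nitrogen substituent shifts the read-out beyond the scatter, so for compound 3 the expected step is a number 1.6 percentage points higher from compound 2 to compound 3 (within the scatter), a change of no consequence. Compound 3 is therefore estimated at 63%, with a range from 48% to 78%.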

Compound 3, largest response reached (reported as efficacy), in percent of the reference or control that the assay uses: 68.1%
Estimate against measurement, compound 3: 5.1 percentage points below, within the range that was stated.
By their numbers in this assay, from the lowest: compounds 2, 3 and 1 (each within the scatter of the next).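

In this assay, cyclobutyl in place of cyclopropyl on a saturated chain carbon bound to an amide-type nitrogen gives a number 6.7 percentage points higher from compound 2 to compound 3 (within the scatter), so the maximal response does not tell these two rings apart at this place. Cyclobutylmethyl in place of 1,2-dimethylpropyl on the same nitrogen gives a number 1.2 percentage points lower from compound 1 to compound 3 (within the scatter), which adds a second ring-bearing group to the earlier comparison and leaves all three groups on this nitrogen within the scatter of one another, so none of the three stands out in this read-out. No measurement is available that would account for these values or connect them to any property of the groups.

All three groups shown are built of carbon only, so it remains open whether a group carrying a heteroatom, such as a hydroxyethyl chain, a methoxyethyl chain or a tetrahydropyranyl ring, would move the maximal response beyond the scatter. Equally open, as far as these compounds go, is whether a larger carbon group on this nitrogen, such as cyclohexylmethyl, benzyl or a longer chain, would do so.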